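Amide swap on a stilbene acrylamide: octyl to pyrrolidine

A few compounds are considered here, and "the series" means these few. Any claim that something is new, unique, unknown or untested is made for them only; others in the source may bear on it.

Measured compounds:
Compound 1, `COc1ccc(/C=C/c2cc(OC)cc(OC)c2/C=C/C(=O)N2CCN(C)CC2)cc1`, gives 2290 nM.
Compound 2, `CCCCCCCCNC(=O)/C=C/c1c(/C=C/c2ccc(OC)cc2)cc(OC)cc1OC`, gives 4280 nM.

Both compounds were tested in a functional assay on MCF7 cells (Homo sapiens) for inhibition, read by MTT assay, with a stated time of 48 h; a higher number here means a weaker inhibitor, a lower number a stronger inhibitor. Compound 2 holds the highest number of the two, with compound 1 the nearest by a 1.9-fold higher number from compound 1 to compound 2 (0.27 log units; within the scatter). Compound 3, `COc1ccc(/C=C/c2cc(OC)cc(OC)c2/C=C/C(=O)N2CCCC2)cc1`, is not yet measured; it differs from compound 2 by pyrrolidin-1-yl in place of octylamino on a carbonyl carbon. For the measured compounds named here, the only measured step that bears on this change is the one at the same carbonyl carbon, from compound 1 to compound 2, which exchanged one amide substituent for another and stayed within the scatter. The shared core is left untouched. Going by the values given here, with only that step to go on, no shift beyond the scatter is expected for compound 3, so the estimated step is a 1.6-fold lower number from compound 2 to compound 3 (0.22 log units; within the scatter). Compound 3 is therefore expected to give about 2600 nM, within the range 900 nM to 7500 nM.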

Compound 3, half-maximal inhibitory concentration: 4200 nM
Compound 3: the middle estimate sits 1.6-fold (0.21 log units) below what was measured, within the range that was stated.
By their numbers in this assay, from the lowest: compounds 1, 3 and 2 (each within the scatter of the next).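

In this assay, the exchange of octylamino for pyrrolidin-1-yl on the carbonyl carbon gives a 1.0-fold lower number from compound 2 to compound 3 (0.01 log units; within the scatter), even though it removes the amide hydrogen, brings in a five-membered ring and leaves a smaller group. The second comparison, a 1.8-fold higher number from compound 1 to compound 3 (0.26 log units; within the scatter), likewise stays within the scatter, so 4-methylpiperazin-1-yl, octylamino and pyrrolidin-1-yl cannot be told apart at this position in these three compounds. Nothing available accounts for this similarity.

The compounds shown leave open whether a carboxylic acid on the same double-bonded chain carbon, a primary amide or a morpholin-4-yl group would shift the number beyond the scatter. They also leave open whether changes to the shared core would matter more than changes to the amide substituent.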